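Replacing the chloro substituent of compound 1 with methylpyrazole

A few compounds are considered here, and "the series" means these few. Any claim that something is new, unique, unknown or untested is made for them only; others in the source may bear on it.

Compound 1 `COc1cc(-c2ccnc3cc(-c4ccc(Cl)cc4)nn23)cc(OC)c1OC` gives 4090 nM in a functional assay on B16-F0 cells (Mus musculus) for inhibition, read by CCK-8 assay, with a stated time of 48 h (a higher number here means a weaker inhibitor, a lower number a stronger inhibitor), the highest number of the three measured. Compound 2 `COc1cc(-c2ccnc3cc(-c4ccc5cc[nH]c5c4)nn23)cc(OC)c1OC` gives 55 nM and compound 3 `COc1cc(-c2ccnc3cc(-c4ccc5ccn(C)c5c4)nn23)cc(OC)c1OC` gives 657 nM. Compound 4 `COc1cc(-c2ccnc3cc(-c4ccc(-c5cnn(C)c5)cc4)nn23)cc(OC)c1OC` differs from compound 1 by 1-methyl-1H-pyrazol-4-yl in place of chloro on an aromatic carbon. For the measured compounds named here, no measured step touches only this position; the nearest are a 74-fold lower number from compound 1 to compound 2 (1.87 log units; beyond the scatter) and a 6.2-fold lower number from compound 1 to compound 3 (0.79 log units; beyond the scatter), each exchanging the whole 4-chlorophenyl for a larger aromatic group, while a 12-fold higher number from compound 2 to compound 3 (1.08 log units; beyond the scatter) shows that methyl on the aromatic nitrogen raised the number. Growing the aryl end has so far lowered the number in compounds 2 and 3, so a modest drop is expected for compound 4, estimated as a 3.4-fold lower number from compound 1 to compound 4 (0.53 log units; beyond the scatter). Compound 4 is expected at 1200 nM, within 300 nM to 4500 nM.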

Compound 4, half-maximal inhibitory concentration: 1240 nM
The estimate for compound 4 lay 1.0-fold (0.01 log units) below the measured number; low and high end bracket the measured number.
By their numbers in this assay, from the lowest: compound 2; then compounds 3 and 4 (each within the scatter of the next); then compound 1.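

With the phenyl ring kept and only the chloro exchanged, 1-methyl-1H-pyrazol-4-yl in this assay gives a 3.3-fold lower number from compound 1 to compound 4 (0.52 log units; beyond the scatter). This position, para to a large group, therefore accepts a five-membered aromatic ring in place of chloro, and the number falls beyond the scatter without the 4-chlorophenyl being replaced as a whole. No evidence available here explains this step. Still open, going by these compounds, is whether the pyrazole ring or its methyl accounts for the step, which the unmethylated 1H-pyrazol-4-yl would test. Also open, on these data alone, is how a non-aromatic group such as morpholine or a simple amine would behave here.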